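The source may hold more compounds than are shown below. What is called first, only, known or untested is meant among the compounds shown, and "the series" means these compounds.

Measured so far:
compound 1 `COc1ccc(-c2cc(-c3cc(C(C)C)c(O)cc3C)[nH]c(=O)c2C#N)cc1`: 47.5%
compound 2 `COc1cc(-c2cc(-c3cc(C(C)C)c(O)cc3C)[nH]c(=O)c2C#N)ccc1O`: 42%

In a functional assay for inhibition, tested at 80 ug/mL (a lower number here means a weaker effect, a higher number a stronger effect of the compound at the concentration tested), compound 1 gives 47.5%, and compound 2 gives 42%. Among the compounds with values here, the only measured step between them, a number 5.5 percentage points lower from compound 1 to compound 2 (within the scatter), is a change on an aromatic carbon and falls within the scatter. Compound 2 thus stands at the lower of the two numbers, but its distance to compound 1 is within the scatter, so no order between the two can be read from this.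

Compound 3 `Cc1cc(O)c(C(C)C)cc1-c1cc(-c2ccc(N(C)C)cc2)c(C#N)c(=O)[nH]1` has not yet been measured in this assay. It differs from compound 2 by 4-(dimethylamino)phenyl in place of 4-hydroxy-3-methoxyphenyl on an aromatic carbon. Within the data shown here, the one measured step bears on this change only loosely, as it also exchanged a group on an aromatic carbon, and it was within the scatter. On that basis no step beyond the scatter is expected in this assay. Compound 3 is therefore expected to give about 44%, between 25% and 63%. This corresponds to an expected step of a number 2 percentage points higher from compound 2 to compound 3 (within the scatter).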

Compound 3, a percentage reported as inhibition, at one concentration (the size of the read-out at that concentration, not a potency): 66.5%
For compound 3 the middle estimate is 22.5 percentage points below the measured one; measured number outside the range, above it.
By their numbers in this assay, from the lowest: compounds 2 and 1 (each within the scatter of the next); then compound 3.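

At this position, on the aromatic carbon opposite the ring nitrogen, the aryl exchange seen earlier stayed within the scatter, but in this assay the read-out moves with 4-(dimethylamino)phenyl, a number rising a number 24.5 percentage points higher from compound 2 to compound 3 (beyond the scatter) as the reading. The comparison with the 4-methoxyphenyl compound points the same way, with dimethylamino in place of methoxy giving a number 19 percentage points higher from compound 1 to compound 3 (beyond the scatter) as the reading, so the position does respond to the group carried on this phenyl ring. No measurement offered here accounts for that rise.

The compounds shown leave open whether the nitrogen itself matters or the particular dimethylamino group, which an unsubstituted amino group or a diethylamino group would test. They also leave open whether a morpholine at the same place on the phenyl ring would keep the higher reading.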